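This account rests on a few compounds, and the source may have more. Where it says the series, first, only, none or still open, it means among the compounds named here.

For the measured compounds named here, in an ADME assay on microsomes from liver (Canis lupus familiaris) for metabolic stability, read by LC-MS, using NADPH, with a stated time of 30 min, tested at 1 uM (a lower number here means that less of the compound is left, a higher number that more of the compound is left), compound 2 `C=CC(=O)Nc1cc(Nc2nccc(Nc3ccccc3S(=O)(=O)C(C)C)n2)c(OC)cc1N(C)CCN(C)C` gives 48%, the higher of the two numbers measured so far, while compound 1 `C=CC(=O)Nc1cc(Nc2ncc(Cl)c(Nc3ccccc3S(=O)(=O)C(C)C)n2)c(OC)cc1N(C)CCN(C)C` gives 17%. Compound 3 `C=CC(=O)Nc1cc(Nc2ncc(I)c(Nc3ccccc3S(=O)(=O)C(C)C)n2)c(OC)cc1N(C)CCN(C)C` has not yet been measured. It differs from compound 2 by a single change, (iodo in place of hydrogen on an aromatic carbon), that is, iodo in place of hydrogen on an aromatic carbon. Compound 1 carries chloro at that same place, so one measured step bears on this change: a number 31 percentage points higher from compound 1 to compound 2 (beyond the scatter), a large step beyond the scatter, made by hydrogen in place of chloro. Compound 3 reverses that exchange, but with iodo rather than chloro. Going by the values given here, no iodo compound has been measured in this assay, so the expectation rests on this one pair alone. Going by the value of compound 1, a large step downward is expected, of about the same size as the measured one, and the expected change is a number 30 percentage points lower from compound 2 to compound 3 (beyond the scatter). The estimated value for compound 3 is 18%, with an expected range from 6% to 36%.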

Compound 3, percent of the compound remaining: 19%
Beside the measured number, compound 3's estimate is 1 percentage points below it; the range from low to high includes it.
By their numbers in this assay, from the lowest: compounds 1 and 3 (each within the scatter of the next); then compound 2.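

In this assay, iodo in place of hydrogen on this aromatic carbon gives a number 29 percentage points lower from compound 2 to compound 3 (beyond the scatter), so the drop seen earlier with chloro alone also appears with a second, larger halogen. Exchanging the two halogens directly gives a number 2 percentage points higher from compound 1 to compound 3 (within the scatter), which means this assay does not tell chloro and iodo apart at this place; across these three compounds, the clear difference lies between hydrogen and either halogen. Nothing at hand gives a reason for this difference, and no supporting measurement accompanies these values.

The compounds shown carry only hydrogen, chloro or iodo at this place, so it remains open whether a methyl, a nitrile or an amine there would give a number close to that of hydrogen or close to those of the two halogens in this assay. On these data alone, all three compounds also share everything else in their structures, so it is equally open whether the gap between hydrogen and the halogens would keep its size if another part of the shared core were changed.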